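The source may report more compounds than this note shows. Statements on the series, on what has been measured and on what is new or still open speak of the compounds shown alone.

Measured compounds:
Compound 1, `CCc1cccc2c(OC)c(-c3occ(C)c3C(=O)NC)ccc12`, gives > 10 ug/mL in a functional assay on MDA-MB-231 cells (Homo sapiens) for cytotoxicity, read by MTT assay, with a stated time of 72 h; on this read-out lower numbers stand for an effect already at smaller amounts and higher numbers for an effect only at larger amounts of compound.
Compound 2, `CCc1cccc2c(OC)c(-c3occ(C)c3C(=O)On3nnc4ccccc43)ccc12`, gives > 10 ug/mL in this assay.
Compound 3, `CCOc1c(-c2occ(C)c2C(=O)OC)ccc2c(CC)cccc12`, gives 1.2 ug/mL in this assay.

The value of compound 1 is a limit of the assay, not a number. The value of compound 2 is likewise a limit. Compound 1 therefore stands at the limit of > 10 ug/mL in this assay, at which 2 of the 3 values shown sit, and its place among the three cannot be read more closely. Among the measured compounds shown here, the only step between compounds that differ in one place is a step that the two limits leave unreadable from compound 1 to compound 2, which the two limits leave unreadable. For the measured compounds named here, compound 3 differs from compound 1 in two places, so no single step joins them; their two values show only that one member of this series does reach a number within the measured range.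

Compound 4, `CCc1cccc2c(OC)c(-c3occ(C)c3COCC(F)(F)F)ccc12`, is not yet measured. It differs from compound 1 by (2,2,2-trifluoroethoxy)methyl in place of methylcarbamoyl on an aromatic carbon. Going by the values given here, no measured step covers this exchange, and the one step that is known gives no size. The expectation for compound 4 thus rests on little more than the number seen for compound 3. On that basis the step of an at least 2.0-fold lower number from compound 1 to compound 4 (0.30 log units; that floor lies within the scatter) is expected to bring compound 4 to a readable value. Compound 4 is estimated at 5 ug/mL, within a range from 1.5 ug/mL to 20 ug/mL.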

Compound 4, concentration for half-maximal effect: 5.3 ug/mL
Estimate against measurement, compound 4: 1.1-fold (0.03 log units) below; low and high end bracket the measured number.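

In this assay compound 1 gives > 10 ug/mL, which is a limit of the assay and not a number. Exchanging its methylcarbamoyl for (2,2,2-trifluoroethoxy)methyl on the same aromatic carbon of the five-membered ring gives an at least 1.8-fold lower number from compound 1 to compound 4 (0.27 log units; that floor lies within the scatter), so a single change at this position is enough to bring the core of compound 1 to a readable value, with a group that has no carbonyl and no hydrogen-bond donor. The true size of this step stays unknown because its starting point is only a limit: the limit of > 10 ug/mL in this assay, at which 2 of the 4 values shown sit.

The exchange alters several things at once, namely the carbonyl, the amide hydrogen, the number of heavy atoms and the presence of fluorine, and the compounds shown do not separate these differences from one another. A plain ethoxymethyl group without the fluorine atoms, or an amine or a carboxylic acid on the same carbon, would help to show which part of the new group goes with the readable value.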